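Aryl swap at the chain end of the propanoyl series

This account rests on a few compounds, and the source may have more. Where it says the series, first, only, none or still open, it means among the compounds named here.

Three compounds share one core and differ only in the aryl group on a saturated chain carbon, two bonds along the chain from a carbonyl carbon. Compound 1 `Cc1cccc(CCC(=O)N2CCN(c3ccc(C(F)(F)F)cc3[C@@H](N)CC(C)C)CC2)c1` gives 2100 nM in an assay on HEK293 cells for displacement of a labelled ligand from Melanocortin receptor 4 (Homo sapiens); on this read-out lower numbers stand for stronger inhibition and higher numbers for weaker inhibition. Compound 2 `CC(C)C[C@H](N)c1cc(C(F)(F)F)ccc1N1CCN(C(=O)CCc2c(Cl)cccc2Cl)CC1` gives 2600 nM, and the step of a 1.2-fold higher number from compound 1 to compound 2 (0.09 log units; within the scatter) sits within the scatter. Compound 3 `COc1cc(OC)c(OC)cc1CCC(=O)N1CCN(c2ccc(C(F)(F)F)cc2[C@@H](N)CC(C)C)CC1` gives 6100 nM, the highest of the three numbers, with steps a 2.9-fold higher number from compound 1 to compound 3 (0.46 log units; beyond the scatter) and a 2.3-fold higher number from compound 2 to compound 3 (0.37 log units; beyond the scatter), both modest but beyond the scatter.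

Compound 4 `Cc1[nH]c2ccccc2c1CCC(=O)N1CCN(c2ccc(C(F)(F)F)cc2[C@@H](N)CC(C)C)CC1` carries the change (2-methyl-1H-indol-3-yl in place of 2,4,5-trimethoxyphenyl on a saturated chain carbon, two bonds along the chain from a carbonyl carbon). The aryl group leaving is the one that gave the highest number; the two other aryl groups seen so far gave lower numbers by modest amounts, as the steps from compound 1 and compound 2 to compound 3 show. Going by the values given here, the entering group has no counterpart among the measured compounds, so the bearing of these steps is only that this position tolerates different aryl groups with changes of modest size. A modest step towards a lower number is therefore expected, roughly reversing the step from compound 1 to compound 3.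

Compound 4 is expected to give 2500 nM, between 800 nM and 8000 nM, a step of a 2.4-fold lower number from compound 3 to compound 4 (0.39 log units; beyond the scatter) from compound 3.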

Compound 4, inhibition constant: 1600 nM
For compound 4 the middle estimate is 1.6-fold (0.19 log units) above the measured one, and the stated range covers the measured number.
By their numbers in this assay, from the lowest: compounds 4, 1 and 2 (each within the scatter of the next); then compound 3.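

Notes on the 2-methyl-1H-indol-3-yl entry: in this assay this position accepts a group with one five-membered aromatic ring with 1 hetero atom and one six-membered aromatic ring of carbon only, and a 3.8-fold lower number from compound 3 to compound 4 (0.58 log units; beyond the scatter) is a modest step beyond the scatter. Against the other two aryl groups, a 1.6-fold lower number from compound 2 to compound 4 (0.21 log units; within the scatter) and a 1.3-fold lower number from compound 1 to compound 4 (0.12 log units; within the scatter) both lie within the scatter, so 2-methyl-1H-indol-3-yl, 3-methylphenyl and 2,6-dichlorophenyl cannot be ordered on this read-out, and among the four compounds only compound 3, with 2,4,5-trimethoxyphenyl, stands apart from the rest. No measurement at hand explains why compound 3 separates from the other three compounds.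

Open, on these data alone, is which part of the entering group carries the result: the ring hydrogen on nitrogen, the methyl, or the second ring, a question that a plain phenyl ring, an unsubstituted indole or an indole with a methyl in place of that hydrogen would address. Also open, as far as these compounds go, is whether the position tolerates anything other than an aryl group at the chain end, such as an amine or a carboxylic acid, and whether a longer chain in place of the propanoyl link would move the number at all.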